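Pyridine series: from methoxy to pyrrolidin-1-yl

The source may report more compounds than this note shows. Statements on the series, on what has been measured and on what is new or still open speak of the compounds shown alone.

Measured so far in a physicochemical assay for solubility, measured as kinetic solubility; a lower number here means a less soluble compound, a higher number a more soluble compound:
- compound 1 `Cc1cc(-c2noc([C@H](C)NC(=O)c3cc(C(F)(F)F)nn3C)n2)ccn1` gives 179000 nM
- compound 2 `COc1cc(-c2noc([C@H](C)NC(=O)c3cc(C(F)(F)F)nn3C)n2)ccn1` gives 156000 nM

The two values lie within the scatter of each other, so compound 2 stands level with compound 1 in this assay on these numbers.

Compound 3 `C[C@H](NC(=O)c1cc(C(F)(F)F)nn1C)c1nc(-c2ccnc(N3CCCC3)c2)no1` is not yet measured. It carries pyrrolidin-1-yl in place of methoxy on an aromatic carbon, next to the ring nitrogen (pyrrolidin-1-yl in place of methoxy on an aromatic carbon).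

Within the data shown here, only one measured step bears on this place, methoxy in place of methyl (a 1.1-fold lower number from compound 1 to compound 2 (0.06 log units; within the scatter)), and it stays within the scatter. Among the measured compounds shown here, no measured compound has a ring-bearing group here, so that step is a weak guide. A modest move to a lower number is expected, held loosely, with no change beyond the scatter still possible. The expected step is a 1.4-fold lower number from compound 2 to compound 3 (0.15 log units; within the scatter) (an estimate only). For compound 3 the estimated value is 110000 nM (expected range 40000 nM to 190000 nM).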

Compound 3, solubility: 41000 nM
Estimate against measurement, compound 3: 2.7-fold (0.43 log units) above; low and high end bracket the measured number.
By their numbers in this assay, from the lowest: compound 3; then compounds 2 and 1 (each within the scatter of the next).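

In this assay, the aromatic carbon next to the ring nitrogen is shown to respond to the group it carries: pyrrolidin-1-yl in place of methoxy gives a 3.8-fold lower number from compound 2 to compound 3 (0.58 log units; beyond the scatter) and pyrrolidin-1-yl in place of methyl gives a 4.4-fold lower number from compound 1 to compound 3 (0.64 log units; beyond the scatter) at the same place. Compound 1 and compound 2 stand within the scatter of each other, so among these three groups only pyrrolidin-1-yl, the one with a ring, separates from the rest. No measurement at hand accounts for this step.

Still open, as far as these compounds go, is whether the step goes with the ring itself or with the nitrogen joined to the aromatic carbon, a question that an open-chain dimethylamino group at this place would address. A morpholine or a smaller azetidine here would show how far the step depends on the make-up and size of the ring.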